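Amide substituent change on the shared core in rat brain

A few compounds are considered here, and "the series" means these few. Any claim that something is new, unique, unknown or untested is made for them only; others in the source may bear on it.

Measured compounds:
compound 1, `Cc1c(C)c2c(c(C)c1O)CCC(C)(C(=O)N1CCNCC1)O2`, 10000 nM
compound 2, `Cc1c(C)c2c(c(C)c1O)CCC(C)(C(=O)Nc1ccncc1)O2`, 2300 nM

Within the data shown here, in a functional assay (brain) for inhibition, with Rattus norvegicus as the target (on this read-out lower numbers stand for stronger inhibition and higher numbers for weaker inhibition), compound 2 gives the lower of the two numbers measured so far. Among the measured compounds shown here, its nearest neighbour is compound 1, and the single known step, a 4.3-fold lower number from compound 1 to compound 2 (0.64 log units; beyond the scatter), separates them beyond the scatter. Compound 3, `Cc1c(C)c2c(c(C)c1O)CCC(C)(C(=O)NCCN(C)C)O2`, has not yet been measured. It differs from compound 2 in one place: 2-(dimethylamino)ethyl in place of pyridin-4-yl on an amide-type nitrogen. For the measured compounds named here, only one measured step bears on this change, a 4.3-fold lower number from compound 1 to compound 2 (0.64 log units; beyond the scatter), in which the piperazin-1-yl group on the carbonyl carbon gave way to (pyridin-4-yl)amino. Compound 3 moves in the opposite direction, from the ring group back to an open chain carrying a nitrogen, though the chain is not the piperazin-1-yl of compound 1, so the step is not a simple reversal. The expectation is therefore a modest upward step, a 2.2-fold higher number from compound 2 to compound 3 (0.34 log units; beyond the scatter), toward the number of compound 1 without necessarily reaching it. For compound 3 the estimated value in this assay is 5000 nM, with a range from 1800 nM to 14000 nM.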

Compound 3, half-maximal inhibitory concentration: 8700 nM
Compound 3: the middle estimate sits 1.7-fold (0.24 log units) below what was measured, within the range that was stated.
By their numbers in this assay, from the lowest: compound 2; then compounds 3 and 1 (each within the scatter of the next).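

Replacing pyridin-4-yl with 2-(dimethylamino)ethyl on the amide-type nitrogen weakens inhibition in this assay (a 3.8-fold higher number from compound 2 to compound 3 (0.58 log units; beyond the scatter)), so the lower number of compound 2 does not survive this exchange. The open chain of compound 3 and the piperazin-1-yl group of compound 1 cannot be told apart (a 1.1-fold lower number from compound 1 to compound 3 (0.06 log units; within the scatter)), which leaves compound 2 alone as the strongest of the three. Compound 3 keeps the amide hydrogen of compound 2, which compound 1 lacks, yet its number stays level with that of compound 1, so the amide hydrogen alone does not secure the lower number seen with compound 2.

The compounds shown leave open whether the lower number of compound 2 follows from the aromatic ring itself or from the ring nitrogen and where it sits, a question that phenyl and pyridin-3-yl on the same amide nitrogen would address. They also leave open whether a longer chain, such as 3-(dimethylamino)propyl, would differ from 2-(dimethylamino)ethyl. No measurement offered here accounts for the differences among these groups.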